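This account rests on a few compounds, and the source may have more. Where it says the series, first, only, none or still open, it means among the compounds named here.

Measured so far:
- compound 1, `Nc1nc(O)c2c(n1)n(C1OC(CO)[C@@H](O)[C@H]1O)c(=O)n2Cc1ccc(Cl)c(Cl)c1`: in a functional assay on the whole organism with Mus musculus as the target (a higher number here means a larger maximal response, a lower number a smaller maximal response), compound 1 gives 0%
- compound 2, `Cn1c(=O)n(C2OC(CO)[C@@H](O)[C@H]2O)c2nc(N)nc(O)c21`: in this assay compound 2 gives 100%

Compound 2 holds the highest of the two numbers in this assay; its nearest neighbour is compound 1, which lies lower by a margin beyond the scatter. The two differ in one place, and the step of a number 100 percentage points higher from compound 1 to compound 2 (beyond the scatter) shows what removing the 3,4-dichlorophenyl from the saturated chain carbon bound to an aromatic nitrogen does.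

Compound 3, `Nc1nc(O)c2c(n1)n(C1OC(CO)[C@@H](O)[C@H]1O)c(=O)n2Cc1ccc([N+](=O)[O-])cc1`, is not yet measured. Compared with compound 2 it carries 4-nitrophenyl in place of hydrogen on a saturated chain carbon bound to an aromatic nitrogen. Among the compounds with values here, only one measured step bears on this change, and it runs the other way: compound 1, which carries the 3,4-dichlorophenyl on a saturated chain carbon bound to an aromatic nitrogen, sits at the bottom, and a number 100 percentage points higher from compound 1 to compound 2 (beyond the scatter) is large. Within the data shown here, whether a 4-nitrophenyl at this position behaves like the 3,4-dichlorophenyl cannot be read from two compounds, but no measured step points the other way. For compound 3 a large drop is therefore expected, about a number 90 percentage points lower from compound 2 to compound 3 (beyond the scatter). The estimate for compound 3 is 10%, in the range 0% to 50%.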

Compound 3, largest response reached (reported as maximal response), in percent of the reference or control that the assay uses: 16%
Compound 3: the middle estimate sits 6 percentage points below what was measured; low and high end bracket the measured number.
By their numbers in this assay, from the lowest: compound 1; then compound 3; then compound 2.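

In this assay a second aryl group on the saturated chain carbon bound to an aromatic nitrogen also removes most of the response (a number 84 percentage points lower from compound 2 to compound 3 (beyond the scatter)), so the loss is not confined to the 3,4-dichlorophenyl. The two aryl groups are not interchangeable, however: exchanging 3,4-dichlorophenyl for 4-nitrophenyl gives a modest gain (a number 16 percentage points higher from compound 1 to compound 3 (beyond the scatter)), small against the large gap that separates both aryl compounds from the methyl-bearing compound 2. No measurement on hand accounts for either step.

Still open, from the compounds shown here alone, is whether the loss follows the aromatic ring itself or the chlorine and nitro substituents it carries, a question that an unsubstituted phenyl at this place would address, while a longer chain such as ethyl or propyl would show whether a ring is needed for the loss at all. Also open, going by these compounds, is how far the response can be recovered within the aryl series, for example with a 4-aminophenyl or a 4-carboxyphenyl in place of the 4-nitrophenyl.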